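The source may hold more compounds than are shown below. What is called first, only, known or untested is meant among the compounds shown, and "the series" means these compounds.

Measured compounds:
- compound 1, `Cn1c(COc2cccc(C(=O)O)c2)nc2cnc(Oc3ccc(Cl)c(F)c3)cc21`, 11 ug/mL
- compound 2, `Cn1c(COc2cccc(C(=O)O)c2)nc2cnc(Oc3ccc4c(c3)OCC4)cc21`, 79 ug/mL
- compound 3, `Cn1c(COc2cccc(C(=O)O)c2)nc2ccc(Oc3ccc(Cl)cn3)cc21`, 17 ug/mL

These three compounds share a core and differ only in the aryl group carried on the ether oxygen. In a physicochemical assay for solubility, read by HPLC, measured as thermodynamic solubility, with a stated time of 4 h, at pH 6.8 (a higher number here means a more soluble compound, a lower number a less soluble compound), compound 3 gives 17 ug/mL; the gap between compound 3 and compound 1 is within the scatter, while compound 2 gives a higher number that lies beyond the scatter from compound 3.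

Compound 4, `Cn1c(COc2cccc(C(=O)O)c2)nc2ccc(Oc3ncc(Cl)cc3F)cc21`, is the next compound to be measured in this assay. It differs from compound 3 in one place: fluoro in place of hydrogen on an aromatic carbon.

Within the data shown here, only one step among the measured compounds is available, a 7.2-fold higher number from compound 1 to compound 2 (0.86 log units; beyond the scatter), and it exchanges a whole aryl group rather than adding a single fluoro, so it bears on the present change only loosely. Among the measured compounds shown here, no measured pair shows a fluoro entering in place of hydrogen on a ring that is otherwise kept. On that basis compound 4 is expected to sit close to compound 3, with a 1.4-fold lower number from compound 3 to compound 4 (0.15 log units; within the scatter) as the estimated step, a shift that is not expected to reach beyond the scatter. Compound 4 is therefore estimated at 12 ug/mL, with a range from 5 ug/mL to 30 ug/mL.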

Compound 4, solubility: 10 ug/mL
Compound 4: the middle estimate sits 1.2-fold (0.08 log units) above what was measured; the range from low to high includes it.
By their numbers in this assay, from the lowest: compounds 4, 1 and 3 (each within the scatter of the next); then compound 2.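

In this assay, compounds 3 and 4 are the only pair shown in which a single atom changes on the aryl group carried by the ether oxygen, and the change gives a 1.7-fold lower number from compound 3 to compound 4 (0.23 log units; within the scatter) while keeping the rest of the structure fixed. Among these compounds, at this position, ortho to a large group and two atoms from the ring nitrogen, fluoro in place of hydrogen therefore cannot be told apart from hydrogen in this read-out, whereas the one earlier step, which exchanged a whole aryl group, lies beyond the scatter. No measurement shown gives a reason for this result, so the pair records only the size of the step.

From the compounds shown here alone, whether another small group at this position, such as a methoxy group, an amine or a nitrile, would also stay within the scatter of compound 3 remains open. Going by these compounds, it also remains open whether the same fluoro would give a step of similar size on the 5-chloropyridin-2-yl group if the shared core carried a different substituent in place of the carboxylic acid.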